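From 3,4-difluorophenyl to 4-chlorophenyl on the amide-type nitrogen

The source may hold more compounds than are shown below. What is called first, only, known or untested is meant among the compounds shown, and "the series" means these compounds.

Measured so far in a functional assay on Jurkat cells (Homo sapiens) for inhibition, read by MTT assay, with a stated time of 72 h; a higher number here means a weaker inhibitor, a lower number a stronger inhibitor

- compound 1 `C=C(Br)C(=O)Nc1cccc(/C=C/C(=O)Nc2ccc(F)cc2)c1` gives 6200 nM
- compound 2 `C=C(Br)C(=O)Nc1cccc(/C=C/C(=O)Nc2cccc(F)c2)c1` gives 1000 nM
- compound 3 `C=C(Br)C(=O)Nc1cccc(/C=C/C(=O)Nc2ccc(F)c(F)c2)c1` gives 550 nM

Compound 3 at 550 nM cannot be separated from its nearest neighbour, with a 1.8-fold lower number from compound 2 to compound 3 (0.26 log units; within the scatter) as the gap. The next entry, compound 4 `C=C(Br)C(=O)Nc1cccc(/C=C/C(=O)Nc2ccc(Cl)cc2)c1`, brings 4-chlorophenyl in place of 3,4-difluorophenyl on an amide-type nitrogen as its change, with 4-chlorophenyl in place of 3,4-difluorophenyl on an amide-type nitrogen. Going by the values given here, no measured compound carries chlorine, so the closest match is the 4-fluorophenyl group of compound 1. That group stands against the others in a 6.2-fold lower number from compound 1 to compound 2 (0.79 log units; beyond the scatter) and in an 11-fold lower number from compound 1 to compound 3 (1.05 log units; beyond the scatter) as the two measured steps. A modest to large move to a higher number is therefore expected in this assay for this change. The estimated step is a 4.5-fold higher number from compound 3 to compound 4 (0.66 log units; beyond the scatter) with wide uncertainty. Compound 4 is expected at 2500 nM within an estimated range from 700 nM to 8000 nM as the upper end.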

Compound 4, half-maximal inhibitory concentration: 2600 nM
The estimate for compound 4 lay 1.0-fold (0.02 log units) below the measured number; the range from low to high includes it.
By their numbers in this assay, from the lowest: compounds 3 and 2 (each within the scatter of the next); then compound 4; then compound 1.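

In this assay, chloro in place of fluoro on the same aromatic carbon gives a 2.4-fold lower number from compound 1 to compound 4 (0.38 log units; beyond the scatter), so the identity of the halogen matters at this position, not only where it sits. The gain is partial: 4-chlorophenyl does not reach the other two groups, with a 2.6-fold higher number from compound 2 to compound 4 (0.41 log units; beyond the scatter) and a 4.7-fold higher number from compound 3 to compound 4 (0.67 log units; beyond the scatter). No available data give a reason for these steps. Still open, on these data alone, is how a bromophenyl, methoxyphenyl or trifluoromethylphenyl group on the amide-type nitrogen would compare with these halogenated phenyl groups.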